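Aryl hydrazone variation on a weakly active series

This account rests on a few compounds, and the source may have more. Where it says the series, first, only, none or still open, it means among the compounds named here.

The measured compounds share the core of compound 1 `Cn1c(=O)c(=O)n(C2CCCC2)c2nc(N/N=C/c3ccc(O)c(F)c3)ncc21` and differ only in the aryl group on the carbon with a double bond to nitrogen. In a functional assay on PC-3 cells (Homo sapiens) for antiproliferative activity, read by MTT assay (a lower number here means a stronger inhibitor, a higher number a weaker inhibitor), compound 1 gives 85200 nM. Compound 2 `Cn1c(=O)c(=O)n(C2CCCC2)c2nc(N/N=C/c3ccco3)ncc21` carries a furan-2-yl at that position and in this assay gives 72200 nM; the step of a 1.2-fold lower number from compound 1 to compound 2 (0.07 log units; within the scatter) is within the scatter. Compound 3 `COc1ccc(/C=N/Nc2ncc3c(n2)n(C2CCCC2)c(=O)c(=O)n3C)c(OC)c1` carries a 2,4-dimethoxyphenyl there. For compound 3 this assay reports only a limit, > 100000 nM, not a number. Compound 3 thus sits at the limit of > 100000 nM in this assay, at which 1 of the 3 values shown sits, and the steps of an at least 1.1-fold higher number from compound 1 to compound 3 (0.06 log units; that floor lies within the scatter) and an at least 1.3-fold higher number from compound 2 to compound 3 (0.14 log units; that floor lies within the scatter) are floors that lie within the scatter, so no ordering among the three measured compounds can be claimed.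

Compound 4 `CSc1ccc(/C=N/Nc2ncc3c(n2)n(C2CCCC2)c(=O)c(=O)n3C)cc1` is the next change at the same position: 4-(methylsulfanyl)phenyl in place of 2,4-dimethoxyphenyl on a carbon with a double bond to nitrogen. Going by the values given here, the steps that bear on it are the three aryl exchanges already measured, every one within the scatter despite quite different groups. Nothing here points to a step beyond the scatter; the expected step is an at least 1.1-fold lower number from compound 3 to compound 4 (0.04 log units; that floor lies within the scatter), with a fair chance that compound 4 again reaches only the limit. Compound 4 is therefore estimated at 90000 nM in this assay, within a range of 35000 nM to 250000 nM.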

Compound 4, half-maximal inhibitory concentration: 21000 nM
Beside the measured number, compound 4's estimate is 4.3-fold (0.63 log units) above it; measured number outside the range, below it.
By their numbers in this assay, from the lowest: compound 4; then compounds 2 and 1 (each within the scatter of the next). At a limit, above all of these: compound 3.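

Among the four aryl groups on the carbon with a double bond to nitrogen in this assay, only 4-(methylsulfanyl)phenyl gives steps beyond the scatter (as a 3.4-fold lower number from compound 2 to compound 4 (0.54 log units; beyond the scatter) and as a 4.1-fold lower number from compound 1 to compound 4 (0.61 log units; beyond the scatter)), so the position is not as flat as the exchanges among compound 1, compound 2 and compound 3 made it look. Against 2,4-dimethoxyphenyl the step is also beyond the scatter, but it can be read only as a floor (as an at least 4.7-fold lower number from compound 3 to compound 4 (0.67 log units; beyond the scatter)), and its true size stays unknown. Compound 3 remains a limit in this assay, not a number: the limit of > 100000 nM in this assay, at which 1 of the 4 values shown sits.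

The compounds shown leave open whether the step follows the sulfur atom or the change to a single substituent on the phenyl ring, since 4-(methylsulfanyl)phenyl is the only group here that carries sulfur, and a 4-methoxyphenyl or an unsubstituted phenyl at this position would separate the two readings. They also leave open whether a sulfur group such as 4-(methylsulfonyl)phenyl or a longer 4-(ethylsulfanyl)phenyl would move the number further in either direction.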